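The source may hold more compounds than are shown below. What is called first, only, known or untested is meant among the compounds shown, and "the series" means these compounds.

Working notes on the series. In an ADME assay on J774 cells (Mus musculus) for cytotoxicity, read by MTT assay, with a stated time of 48 h (on this read-out lower numbers stand for stronger inhibition and higher numbers for weaker inhibition), compound 2 (`CC(=O)Nc1cc(/C=C/c2ccccc2)nc2ccccc12`) reads > 25000 nM, which is a limit of the assay and not a number. Compound 1 (`NCCNc1cc(/C=C/c2ccccc2)nc2ccccc12`), with 2-aminoethyl on the same nitrogen, gives 4600 nM in this assay. Compound 3 (`Nc1cc(/C=C/c2ccccc2)nc2ccccc12`) removes the acetyl of compound 2: hydrogen in place of acetyl on a nitrogen on an aromatic ring. This is hydrogen in place of acetyl on a nitrogen on an aromatic ring, or acetamido to amino. Among the measured compounds shown here, one measured step bears on it: an at least 5.4-fold higher number from compound 1 to compound 2 (0.73 log units; beyond the scatter), which lies beyond the scatter and involves the same nitrogen. For the measured compounds named here, no measured compound carries hydrogen there, so that step is only a rough guide to size. A move to a lower number in this assay is expected, of modest size, and a second limit reading remains possible. The expected change is an at least 2.2-fold lower number from compound 2 to compound 3 (0.35 log units; beyond the scatter). For compound 3 the estimate is 11000 nM, with an expected range from 4000 nM to 25000 nM.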

Compound 3, half-maximal inhibitory concentration: 4400 nM
Beside the measured number, compound 3's estimate is 2.5-fold (0.40 log units) above it, and the stated range covers the measured number.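

Removing the acetyl in this assay gives an at least 5.6-fold lower number from compound 2 to compound 3 (0.75 log units; beyond the scatter) and shows that the high reading follows the acetyl itself, not merely the loss of 2-aminoethyl. Hydrogen and 2-aminoethyl on this nitrogen do not separate, with a 1.0-fold lower number from compound 1 to compound 3 (0.02 log units; within the scatter) as the step between them, so among the compounds shown only the acetyl stands apart at this position. As far as these compounds go, compound 2 stands at a limit of the assay, so the full size of the step from it stays unknown: the limit of > 25000 nM in this assay, at which 1 of the 3 values shown sits.

Open, from the compounds shown here alone, is whether other acyl groups, such as propanoyl or benzoyl, read like the acetyl of compound 2. Also open, going by these compounds, is whether a methyl or a longer chain ending in an amine on this nitrogen reads with compound 1 and compound 3.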